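A few compounds are considered here, and "the series" means these few. Any claim that something is new, unique, unknown or untested is made for them only; others in the source may bear on it.

In a functional assay on MCF7 cells (Homo sapiens) for cytotoxicity, read by MTT assay, with a stated time of 24 h, tested at 80 ug/mL (a higher number here means a stronger effect of the compound at the concentration tested, a lower number a weaker effect), compound 2, `Cc1nnc(SCC(=O)Nc2ccc(-c3nc(-c4ccccc4)c(-c4ccccc4)n3C)cc2)s1`, gives 85.2%. Among the compounds with values here, that is the highest of the two numbers measured so far, but the only other number, that of compound 1, `Cn1c(-c2ccc(NC(=O)CSc3nc4ccccc4o3)cc2)nc(-c2ccccc2)c1-c1ccccc1`, which gives 76.3%, lies within the usual scatter of it. Within the data shown here, the single measured step, a number 8.9 percentage points higher from compound 1 to compound 2 (within the scatter), exchanges one ring on the sulfur for another and stays within the scatter. Compound 3, `Cn1c(-c2ccc(NC(=O)CN3CCN(c4ccccc4)CC3)cc2)nc(-c2ccccc2)c1-c1ccccc1`, has not yet been measured; it differs from compound 2 in one place: 4-phenylpiperazin-1-yl in place of (5-methyl-1,3,4-thiadiazol-2-yl)sulfanyl on a saturated chain carbon bound to a carbonyl carbon. Among the measured compounds shown here, no measured step bears directly on this change, because in it the whole (5-methyl-1,3,4-thiadiazol-2-yl)sulfanyl leaves and 4-phenylpiperazin-1-yl enters, whereas the one step seen so far only swapped the ring carried on the sulfur. For the measured compounds named here, the only guidance is that variation at this position has so far stayed within the scatter, so the expected step is about a number 9.2 percentage points lower from compound 2 to compound 3 (within the scatter), no change beyond the scatter, with wider uncertainty than before. Compound 3 is estimated at 76%, with a range from 55% to 92%.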

Compound 3, a percentage reported as activity, at one concentration (the size of the read-out at that concentration, not a potency): 72.5%
Compound 3: middle estimate off by 3.5 percentage points, on the high side, within the range that was stated.
By their numbers in this assay, from the lowest: compounds 3, 1 and 2 (each within the scatter of the next, the first and the last beyond it).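

In this assay, within the data shown here, the whole sulfur-linked group on the saturated chain carbon bound to a carbonyl carbon can be replaced by 4-phenylpiperazin-1-yl, and this gives the first step here to pass the scatter, a number 12.7 percentage points lower from compound 2 to compound 3 (beyond the scatter), although its size is modest. The same entering group, set in place of (1,3-benzoxazol-2-yl)sulfanyl, gives a number 3.8 percentage points lower from compound 1 to compound 3 (within the scatter), so whether this exchange registers as a real difference depends on which of the two sulfur-linked groups it is compared with. The compounds show that the position accepts a sulfur-free group with a non-aromatic ring and still leaves a sizeable read-out, but no measurement gives a reason for either step.

The compounds shown leave open whether the piperazine ring or the phenyl on it accounts for the step, and a piperazine carrying methyl in place of phenyl, or a morpholine, would help to separate the two. Each read-out also comes from a single concentration, so the relative potency of these compounds remains unknown.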